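Aryl to benzyl swap on the ring nitrogen

This account rests on a few compounds, and the source may have more. Where it says the series, first, only, none or still open, it means among the compounds named here.

Compound 1 `CC(C)(C)OC(=O)N1CCN(C(=S)SCc2cn(-c3ccccc3F)nn2)CC1`: 119000 nM
Compound 2 `COc1ccc(Cn2cc(CSC(=S)N3CCN(C(=O)OCc4ccccc4)CC3)nn2)cc1`: 23800 nM
Compound 3 `Fc1ccccc1Cn1cc(CSC(=S)N2CCNCC2)nn1`: 19400 nM

In a functional assay on MGC-803 cells (Homo sapiens) for inhibition, read by MTT assay, with a stated time of 72 h (on this read-out higher numbers stand for weaker inhibition and lower numbers for stronger inhibition), compound 1 has the highest of the three numbers; compound 2 is nearest and compound 3 furthest, and both gaps lie beyond the scatter, so compound 1 is the weakest inhibitor of the three. Compound 4 `CC(C)(C)OC(=O)N1CCN(C(=S)SCc2cn(Cc3ccccc3Cl)nn2)CC1` differs from compound 1 by 2-chlorobenzyl in place of 2-fluorophenyl on an aromatic nitrogen. For the measured compounds named here, no pair of measured compounds isolates this change. The two benzyl-bearing compounds, compound 2 with 23800 nM and compound 3 with 19400 nM, both sit far below compound 1. On that basis a step toward stronger inhibition, beyond the scatter, is expected: a 3.0-fold lower number from compound 1 to compound 4 (0.47 log units; beyond the scatter). Compound 4 is therefore estimated at 40000 nM, with a range from 15000 nM to 110000 nM.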

Compound 4, half-maximal inhibitory concentration: 490 nM
Compound 4: middle estimate off by 82-fold (1.91 log units), on the high side, outside the stated range (below it).
By their numbers in this assay, from the lowest: compound 4; then compounds 3 and 2 (each within the scatter of the next); then compound 1.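

In this assay, the group on the aromatic nitrogen turns out to have a very large effect: with the rest of the molecule unchanged, 2-chlorobenzyl in place of 2-fluorophenyl gives a 240-fold lower number from compound 1 to compound 4 (2.39 log units; beyond the scatter). The earlier compounds shown here differed in several places at once and could not isolate this position. Nothing measured here accounts for the size of this step. On these data alone, the change replaces fluorine with chlorine and phenyl with benzyl together, so it remains open which of the two carries the step. As far as these compounds go, how a 2-chlorophenyl or an unsubstituted benzyl group would behave at this position also remains open.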